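This account rests on a few compounds, and the source may have more. Where it says the series, first, only, none or still open, it means among the compounds named here.

Working notes on the series. Compound 1 `O=C1N=C(C2C(=O)c3ccccc3C2=O)CC(c2ccccc2[N+](=O)[O-])N1` and compound 2 `O=C1N=C(C2C(=O)c3ccccc3C2=O)CC(c2cccc([N+](=O)[O-])c2)N1` share one core and differ only in the aryl group on a saturated ring carbon. In a functional assay on the whole organism for inhibition, with Rattus norvegicus as the target, read by paw edema, with stated times of 30 min and 2 h, at a dose of 10 mg/kg by the oral route (a higher number here means more inhibition at the dose given (going by the name of the read-out), a lower number less inhibition), compound 1 gives 30%. In this assay compound 2 gives 36%. The step of a number 6 percentage points higher from compound 1 to compound 2 (within the scatter) thus separates nothing. Of the two numbers compound 2 carries the greater one, but its nearest neighbour, compound 1, lies within the scatter of it, so no ordering is claimed.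

Compound 3 `O=C1N=C(C2C(=O)c3ccccc3C2=O)CC(c2ccco2)N1` is not yet measured. Its change from compound 2: furan-2-yl in place of 3-nitrophenyl on a saturated ring carbon. Going by the values given here, no measured step exchanges a six-membered aromatic ring for a five-membered one; the only step available, a number 6 percentage points higher from compound 1 to compound 2 (within the scatter), moved the nitro group about the same ring and stayed within the scatter. In the two cases known, the read-out has not responded to the aryl group, so for compound 3 no step beyond the scatter is expected in this assay, a number 6 percentage points lower from compound 2 to compound 3 (within the scatter), though the change is of a different kind and the uncertainty is wide. Compound 3 is estimated at 30%, with a range of 12% to 48%.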

Compound 3, a percentage reported as inhibition, in the whole organism at one dose (the size of the read-out at that dose, not a potency): 25%
Estimate against measurement, compound 3: 5 percentage points above; measured number inside the range.
By their numbers in this assay, from the lowest: compounds 3, 1 and 2 (each within the scatter of the next, the first and the last beyond it).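

Going by these compounds alone, the saturated ring carbon next to the ring nitrogen is no longer silent in this assay: the exchange of 3-nitrophenyl for furan-2-yl gives a number 11 percentage points lower from compound 2 to compound 3 (beyond the scatter) and is the first step to pass beyond the scatter. The separation is narrow, as the exchange of 2-nitrophenyl for furan-2-yl gives a number 5 percentage points lower from compound 1 to compound 3 (within the scatter) and so does not separate the two compounds, which means the furan-2-yl change cannot be called a general loss against both nitrophenyl groups. Nothing measured alongside these numbers accounts for the step.

The compounds shown leave open whether the step goes with the change from a six-membered to a five-membered aromatic ring or with the loss of the nitro group, a question that unsubstituted phenyl and thiophen-2-yl at this carbon would help to separate. Also open, on these data alone, is how this position responds to groups of another kind, such as an aminophenyl group, a carboxylic acid on the aryl ring or a longer alkyl chain in place of the aromatic ring.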